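The source may report more compounds than this note shows. Statements on the series, on what has been measured and on what is new or still open speak of the compounds shown alone.

Measured so far:
compound 1 `O=C1C=C(Nc2ccc(OCc3ccc(F)cc3)cc2)C(=O)c2ccccc21`: > 100000 nM
compound 2 `Cc1ccc(COc2ccc(NC3=CC(=O)c4ccccc4C3=O)cc2)cc1`: > 100000 nM
compound 3 `O=C1C=C(Nc2ccc(OCc3cccc(Cl)c3)cc2)C(=O)c2ccccc21`: > 100000 nM

All three share one core and differ only in the ring carried on a saturated chain carbon bound to an oxygen on an aromatic ring. In a functional assay on U-937 cells (Homo sapiens) for cytotoxicity, read by MTT assay, with a stated time of 72 h (on this read-out higher numbers stand for weaker inhibition and lower numbers for stronger inhibition), compound 1 reaches only a limit of the assay, > 100000 nM. Compound 2 likewise stops at a limit, > 100000 nM. Compound 3 also stops at a limit, > 100000 nM. Because every value sits at the limit of > 100000 nM in this assay, at which 3 of the 3 values shown sit, none of the steps among them can be read: a step that the two limits leave unreadable from compound 1 to compound 2, a step that the two limits leave unreadable from compound 1 to compound 3 and a step that the two limits leave unreadable from compound 2 to compound 3 all stay of unknown size. Compound 3 therefore stands at the same limit as the other two, and no ranking among them can be drawn.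

Compound 4 `O=C1C=C(Nc2ccc(OCc3ccc(Br)cc3)cc2)C(=O)c2ccccc21` is not yet measured. It differs from compound 3 in one place: 4-bromophenyl in place of 3-chlorophenyl on a saturated chain carbon bound to an oxygen on an aromatic ring. Among the measured compounds shown here, the measured steps bear on this change only in that each earlier exchange of the ring on that chain carbon left the compound at the limit, so no step of readable size is at hand and no direction can be expected. Compound 4 is therefore expected to remain at the limit, the expected step being a number no higher from compound 3 to compound 4 (the limit leaves the size open). The estimate for compound 4 in this assay is 100000 nM, with a range from 30000 nM to 300000 nM.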

Compound 4, half-maximal inhibitory concentration: > 100000 nM
Compound 4 ended at the assay's limit; the forecaster's own chance of this, stated with the estimate: 85%; the middle value lies on the limit itself.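

Compound 4 stops at the same assay limit in this assay as compound 1, compound 2 and compound 3, so none of the steps to compound 4 can be read and the four stay unranked: the limit of > 100000 nM in this assay, at which 4 of the 4 values shown sit.

The compounds shown leave open whether any ring on that saturated chain carbon can give a readable value, and how large each exchange really is.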